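Inverting one stereocentre: from compound 2 to compound 3

A few compounds are considered here, and "the series" means these few. Any claim that something is new, unique, unknown or untested is made for them only; others in the source may bear on it.

Compound 1 `CO[C@H]1CCN(c2cc(NC(=O)N3CCCc4cc(CN5CCOCC5=O)c(C=O)nc43)ncc2C#N)C1`: 6460 nM
Compound 2 `COCCNc1cc(NC(=O)N2CCCc3cc(CN4CC[C@H](OC)C4=O)c(C=O)nc32)ncc1C#N`: 6480 nM

In an ADME assay on the whole organism (Rattus norvegicus, strain Sprague-Dawley) for pharmacokinetics, read by LC-MS, with stated times of 5 min and 24 h, at a dose of 5 mg/kg by the oral route (a lower number here means less compound in the circulation, a higher number more compound in the circulation at the dose given), compound 2 gives 6480 nM and compound 1 gives 6460 nM, and these two values lie within the usual scatter of each other. Compound 3 `COCCNc1cc(NC(=O)N2CCCc3cc(CN4CC[C@@H](OC)C4=O)c(C=O)nc32)ncc1C#N` has not yet been measured. Its relation to compound 2 is simple: the two compounds have the same atoms and bonds and differ only in configuration as drawn: 1 of 1 stereo elements differ; a stereocentre at a saturated ring carbon is drawn S in compound 2 and R in compound 3. Going by the values given here, no two measured compounds differ in one place only, so the data hold no direct guide to the size of such a step. With nothing to favour either direction, no change beyond the scatter is expected in this assay. The estimated step is a 1.2-fold lower number from compound 2 to compound 3 (0.07 log units; within the scatter), which would stay within that scatter. For compound 3 the expected value is 5500 nM, with an estimated range from 2500 nM to 11000 nM.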

Compound 3, maximal plasma concentration: 7410 nM
Estimate against measurement, compound 3: 1.3-fold (0.13 log units) below; the range from low to high includes it.
By their numbers in this assay, from the lowest: compounds 1, 2 and 3 (each within the scatter of the next).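

In this assay the set now holds its first comparison in one place, a 1.1-fold higher number from compound 2 to compound 3 (0.06 log units; within the scatter). At this saturated ring carbon, then, the configuration drawn as S and the one drawn as R are not separated by the maximal plasma concentration after the oral dose. The comparison can be read as one of configuration alone: the fact that compounds 2 and 3 differ only in the configuration as drawn

On these data alone, whether a hydroxyl group or a longer alkoxy chain in place of the methoxy group of compound 2 and compound 3 would move the number beyond the scatter remains open. As far as these compounds go, compound 1 differs from compound 2 in more than one place, so the effect of its ring-bound amine on the nitrile-bearing ring, taken alone, also remains open.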